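Chlorine Pattern Shift in a Weak Cytotoxicity Series

The source may report more compounds than this note shows. Statements on the series, on what has been measured and on what is new or still open speak of the compounds shown alone.

Among the measured compounds shown here, compound 2 `COc1ccc(/C=C2\CCC/C(=C\c3ccccc3Cl)C2=O)cc1OC` is the only member of this set with a measured number: in a functional assay on MCF7 cells (Homo sapiens) for cytotoxicity, read by MTT assay, with a stated time of 72 h (on this read-out higher numbers stand for weaker inhibition and lower numbers for stronger inhibition), compound 2 gives 10400 nM. Compound 1 `COc1cccc(/C=C2\CCC/C(=C\c3cccc(Cl)c3Cl)C2=O)c1OC` reaches only a limit, > 20000 nM, which is the limit of > 20000 nM in this assay, at which 1 of the 2 values shown sits. Compound 3 `COc1ccc(/C=C2\CCC/C(=C\c3ccc(Cl)c(Cl)c3)C2=O)cc1OC` is not yet measured; it differs from compound 2 by 3,4-dichlorophenyl in place of 2-chlorophenyl on a double-bonded chain carbon bound to a double-bonded ring carbon. For the measured compounds named here, no measured pair shows this change, so any expectation rests on compound 2 alone. The expected step, a 1.3-fold lower number from compound 2 to compound 3 (0.11 log units; within the scatter), is small and in no firm direction beyond the scatter. Compound 3 is therefore estimated at 8000 nM, within 3000 nM to 25000 nM in this assay.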

Compound 3, half-maximal inhibitory concentration: 4400 nM
Compound 3: the middle estimate sits 1.8-fold (0.26 log units) above what was measured; low and high end bracket the measured number.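

On the double-bonded chain carbon bound to a double-bonded ring carbon, 3,4-dichlorophenyl in place of 2-chlorophenyl gives a 2.4-fold lower number from compound 2 to compound 3 (0.37 log units; beyond the scatter). Among the compounds shown here, this is the first readable step in this assay, and it shows that this position responds to a change of the chlorinated phenyl group, though only modestly. Compound 1 remains a limit and gives no step: the limit of > 20000 nM in this assay, at which 1 of the 3 values shown sits.

This single step cannot separate the added chlorine from its changed place on the ring. As far as these compounds go, how a nitrile or an amine on this phenyl ring would compare remains open.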